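The source may hold more compounds than are shown below. What is called first, only, known or untested is meant among the compounds shown, and "the series" means these compounds.

Of the compounds shown here, three sharing one core have been tested in a functional assay on SMMC-7721 cells (Homo sapiens) for cytotoxicity, read by MTT assay, with a stated time of 24 h; a lower number here means a stronger inhibitor, a higher number a weaker inhibitor: compound 1 `CN1C/C(=C\c2cccnc2)C(=O)/C(=C/c2ccccc2F)C1` gives 5420 nM, compound 2 `O=C1/C(=C/c2cccnc2)CN(S(=O)(=O)c2ccc(Br)cc2)C/C1=C\c1ccccc1F` gives 9100 nM, and compound 3 `CC(=O)Nc1ccc(S(=O)(=O)N2C/C(=C\c3cccnc3)C(=O)/C(=C/c3ccccc3F)C2)cc1` gives 10900 nM. Compound 2 sits within the usual scatter of both other compounds, so it holds no clear rank against either of them.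

The unmeasured compound 4 `O=C1/C(=C/c2cccnc2)CN(S(=O)(=O)c2ccc(Br)cc2)C/C1=C\c1ccccc1C(F)(F)F` differs from compound 2 in one group: trifluoromethyl in place of fluoro on an aromatic carbon. Put simply, this is trifluoromethyl in place of fluoro on an aromatic carbon, ortho to a large group.

Two measured steps offer some guidance, though neither touches this group. The step of a 1.7-fold higher number from compound 1 to compound 2 (0.23 log units; within the scatter) puts (4-bromophenyl)sulfonyl in place of methyl on an amine nitrogen in a ring. The step of a 1.2-fold higher number from compound 2 to compound 3 (0.08 log units; within the scatter) puts acetamido in place of bromo on an aromatic carbon. For the measured compounds named here, both stay within the scatter, but no measurement yet shows what a change at the fluoro position does. The expectation in this assay is therefore a step no larger than the scatter, in neither direction with any confidence.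

The estimated step is a 1.2-fold lower number from compound 2 to compound 4 (0.08 log units; within the scatter). For compound 4 the expected value is 7500 nM, with an estimated range from 3000 nM to 17000 nM.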

Compound 4, half-maximal inhibitory concentration: 5760 nM
Compound 4: middle estimate off by 1.3-fold (0.11 log units), on the high side; measured number inside the range.
By their numbers in this assay, from the lowest: compounds 1, 4, 2 and 3 (each within the scatter of the next).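

For the compounds shown here, this is the first measured change at this position on the aromatic ring, ortho to a large group, and in this assay putting trifluoromethyl in place of fluoro gives a 1.6-fold lower number from compound 2 to compound 4 (0.20 log units; within the scatter). Going from 2-fluorophenyl to 2-(trifluoromethyl)phenyl replaces a group of 1 heavy atom with one of 4 heavy atoms, yet this pair shows no change that can be told apart from the scatter, so this single step gives no sign that the number depends on which of these two groups is present. No measurement of any property of these groups bears on this result, so the data offer no explanation for it.

From the compounds shown here alone, both groups contain fluorine, so it remains open whether a group of a different kind at this place, such as an amine, a carboxylic acid or a longer chain, would also stay within the scatter of compound 2. Also open, going by these compounds, is whether the same exchange would give a step of similar size with the methyl on the ring nitrogen of compound 1 or the acetamido group of compound 3.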